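This account rests on a few compounds, and the source may have more. Where it says the series, first, only, none or still open, it means among the compounds named here.

Compound 1 `CC1=CC[C@H](C(C)(C)NC(=S)N/N=C/c2ccc(O)cc2)CC1` and compound 2 `COc1cc(/C=N/NC(=S)NC(C)(C)[C@H]2CC=C(C)CC2)ccc1O` were both examined in a functional assay on NCI-H460 cells (Homo sapiens) for inhibition, read by sulforhodamine B assay, with a stated time of 48 h; on this read-out lower numbers stand for stronger inhibition of growth and higher numbers for weaker inhibition of growth. For compound 1 the value > 100000 nM is a limit of the assay rather than a number. For compound 2 the value > 100000 nM is likewise a limit. The change methoxy in place of hydrogen on an aromatic carbon therefore yields a step that the two limits leave unreadable from compound 1 to compound 2. Compound 3 `CC1=CC[C@H](C(C)(C)NC(=S)N/N=C(\C)c2ccccc2)CC1` rests on a different core, and the difference between the two cores is not broken down here. In this assay compound 3 gives > 100000 nM, which again is a limit. Compound 4 `COc1ccc(/C(C)=N/NC(=S)NC(C)(C)[C@H]2CC=C(C)CC2)cc1` differs from compound 3 by methoxy in place of hydrogen on an aromatic carbon, the same kind of change as that between compound 1 and compound 2, though the surroundings differ: in compound 4 the methoxy sits para to a large group, whereas in compound 2 it sits ortho to a hydroxy group and meta to a large group. Because all three values sit at the limit of > 100000 nM in this assay, at which 3 of the 3 values shown sit, the step is expected to be a step that the limit leaves unreadable from compound 3 to compound 4. Compound 4 is accordingly expected to give about 150000 nM in this assay, most probably once more as a limit, somewhere within 50000 nM to 500000 nM.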

Compound 4, concentration for 50% growth inhibition: 90600 nM
Beside the measured number, compound 4's estimate is 1.7-fold (0.22 log units) above it; low and high end bracket the measured number.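

On the core of compound 3, methoxy in place of hydrogen on an aromatic carbon gives, in this assay, an at least 1.1-fold lower number from compound 3 to compound 4 (0.04 log units; that floor lies within the scatter), and compound 4 is the only one of the four compounds shown that returns a number rather than a limit. The same change on the core of compound 1 gives a step that cannot be read, so these compounds do not show whether the change carries from one core to the other, and the two steps cannot be set against each other. Even on the core of compound 3 the true size of the step stays open, and it may be no more than scatter, because compound 3 carries only a limit: the limit of > 100000 nM in this assay, at which 3 of the 4 values shown sit.

The compounds shown leave open what an amine, a carboxylic acid or a longer alkoxy chain on that aromatic carbon would do in this assay. They also leave open whether any such group on either core would move the growth inhibition clearly away from the limit.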